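Shortening the Alkyl Chain on Two Related Cores

The compounds below may be only part of what the source reports. "The series", "measured", "known", "first", "only" and "open" are said of these compounds alone.

Compound 1 `CCCCCCCCc1cn([C@H]2C[C@@H]3OP(=O)(O)OC[C@H]3O2)c(=O)[nH]c1=O` and compound 3 `CCCCCCc1cn([C@H]2C[C@@H]3OP(=O)(O)OC[C@H]3O2)c(=O)[nH]c1=O` share one core, while compound 2 `CCCCCCc1cn([C@H]2C[C@H](O)[C@@H](CO)O2)c(=O)[nH]c1=O` and compound 4 `CCCCc1cn([C@H]2C[C@H](O)[C@@H](CO)O2)c(=O)[nH]c1=O` share another; the difference between the two cores is not broken down here. In a functional assay on L1210 cells (Mus musculus) (on this read-out lower numbers stand for stronger inhibition and higher numbers for weaker inhibition), compound 1 gives 164 ug/mL. Compound 3 reaches only a limit of this assay, > 500 ug/mL. Compound 2 gives 172 ug/mL in this assay, a number that sits within the scatter of the number for compound 1.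

The change hydrogen in place of ethyl on a saturated chain carbon, six bonds along the chain from an aromatic carbon produced an at least 3.0-fold higher number from compound 1 to compound 3 (0.48 log units; beyond the scatter), with compound 3 sitting at the limit of > 500 ug/mL in this assay, at which 1 of the 3 values shown sits. Compound 4 carries the same kind of change, (hydrogen in place of ethyl on a saturated chain carbon, four bonds along the chain from an aromatic carbon), but here the saturated chain carbon lies four bonds along the chain from an aromatic carbon rather than six bonds along it. The step expected in this assay is a 3.5-fold higher number from compound 2 to compound 4 (0.54 log units; beyond the scatter). Among the compounds with values here, that expectation rests on an at least 3.0-fold higher number from compound 1 to compound 3 (0.48 log units; beyond the scatter), the one measured example of this kind of change. Compound 4 is therefore expected to give about 600 ug/mL, most likely between 300 ug/mL and 1500 ug/mL, and it may well return only a limit.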

Compound 4, concentration for 50% inhibition: > 500 ug/mL
Compound 4 ended at the assay's limit; the forecaster's own chance of this, stated with the estimate: 60%; the middle value lies beyond the limit too.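

Shortening the chain raised the number on the second core as well: in this assay the change gave an at least 2.9-fold higher number from compound 2 to compound 4 (0.46 log units; beyond the scatter), so its direction carried over from the core of compound 1 to the core of compound 2. Set side by side, the two steps read as follows: the same change on two cores in this assay, an at least 3.0-fold higher number (0.48 log units; beyond the scatter) from compound 1 to compound 3 and an at least 2.9-fold higher number (0.46 log units; beyond the scatter) from compound 2 to compound 4; the limit leaves it open whether they differ. What this does not show is the true size of the change on either core, or whether the two sizes match, since compound 3 and compound 4 each give only a limit and no number: the limit of > 500 ug/mL in this assay, at which 2 of the 4 values shown sit.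

The compounds shown leave open whether a longer chain on either core would lower the number in this assay, and so whether the trend seen with shortening continues in the other direction. They also leave open how a chain carrying an amine or a carboxylic acid would read on these two cores.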